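Urea-to-amide switch with dichlorophenyl: compound 4 outlook

This account rests on a few compounds, and the source may have more. Where it says the series, first, only, none or still open, it means among the compounds named here.

Compound 1 `COc1cc(Cl)cc(-c2nn(-c3cccc(NC(=O)Nc4cccc(C(F)(F)F)c4)c3)cc2-c2ccncc2)c1` is the lowest of the three numbers measured in a functional assay on OVCAR-8 cells (Homo sapiens) for inhibition, read by sulforhodamine B assay, with a stated time of 48 h, tested at 10 uM (on this read-out higher numbers stand for a weaker effect at the one concentration tested and lower numbers for a stronger effect), where compound 1 gives -12.3%. Among the measured compounds shown here, compound 2 `COc1cc(Cl)cc(-c2nn(-c3cccc(NC(=O)Nc4ccc(Cl)c(C(F)(F)F)c4)c3)cc2-c2ccncc2)c1` gives 8.71%, and the single measured step, a number 21 percentage points higher from compound 1 to compound 2 (beyond the scatter), is the only one-place change in hand. For the measured compounds named here, compound 3 `COc1cc(Cl)cc(-c2nn(-c3cccc(NC(=O)c4cc(C(F)(F)F)cc(C(F)(F)F)c4)c3)cc2-c2ccncc2)c1` gives 55.4%, far above compound 1, but it differs from compound 1 in more than one place, so no step is counted for it.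

Compound 4 `COc1cc(Cl)cc(-c2nn(-c3cccc(NC(=O)c4ccc(Cl)c(Cl)c4)c3)cc2-c2ccncc2)c1` is the change (3,4-dichlorophenyl in place of (3-(trifluoromethyl)phenyl)amino on a carbonyl carbon). Going by the values given here, no measured step covers this change directly. Among the compounds with values here, what can be said is that the only other compound without the urea linkage, compound 3, sits at the weak end of the series, and that adding chlorine in compound 2 already moved the number upward beyond the scatter. A step in the same direction, toward a weaker effect, is therefore expected for compound 4, of size a number 47.3 percentage points higher from compound 1 to compound 4 (beyond the scatter). Compound 4 is estimated at 35%, within a range from 5% to 65%.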

Compound 4, a percentage reported as activity, at one concentration (the size of the read-out at that concentration, not a potency): 58.4%
Estimate against measurement, compound 4: 23.4 percentage points below, within the range that was stated.
By their numbers in this assay, from the lowest: compound 1; then compound 2; then compounds 3 and 4 (each within the scatter of the next).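

On the carbonyl carbon, an aryl group in place of the arylamino group gives the same outcome from both urea compounds in this assay: 3,4-dichlorophenyl brings a number 70.7 percentage points higher from compound 1 to compound 4 (beyond the scatter) and a number 49.7 percentage points higher from compound 2 to compound 4 (beyond the scatter) and thus a much weaker effect at the one concentration tested. Compound 3 and compound 4 lie within the scatter of each other, so the dichlorophenyl and bis(trifluoromethyl)phenyl amides are not told apart on this read-out. No measurement available here accounts for the shift.

Still open, from the compounds shown here alone, is whether the weaker effect follows the loss of the urea nitrogen with its hydrogen or the change of aryl substituents, as the two change together in these pairs. A urea carrying the 3,4-dichlorophenyl group would separate the two, and an amide carrying a dimethylamino group or a carboxylic acid on its phenyl ring would test how far this position tolerates other groups.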